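Hydroxymethyl series: benzyl removal and an expected value

The compounds below may be only part of what the source reports. "The series", "measured", "known", "first", "only" and "open" are said of these compounds alone.

Compound 1 `C[Si](C)(C)CCOCn1c(CC(O)COCc2ccccc2)cc(=O)[nH]c1=O` carries a benzyloxy group. In a functional assay on MIA PaCa-2 cells (Homo sapiens) for antiproliferative activity, read by MTT assay, with a stated time of 72 h (a lower number here means a stronger inhibitor, a higher number a weaker inhibitor), compound 1 gives only a limit of the assay, > 100000 nM. Compound 2 `C[Si](C)(C)CCOCn1c(CC(O)CO)cc(=O)[nH]c1=O` differs from it by hydrogen in place of benzyl on an oxygen on a saturated carbon. In this assay compound 2 likewise gives only a limit, > 100000 nM. The step that the two limits leave unreadable from compound 1 to compound 2 therefore cannot be sized. Compound 3 `COCn1c(CC(O)COCc2ccccc2)c(C)c(=O)[nH]c1=O` rests on a different core; the difference between the two cores is not broken down here. In this assay compound 3 also gives only a limit, > 100000 nM. Compound 4 `COCn1c(CC(O)CO)c(C)c(=O)[nH]c1=O` is not yet measured and differs from compound 3 by hydrogen in place of benzyl on an oxygen on a saturated carbon, the same change as from compound 1 to compound 2, at the same place. Because (the limit of > 100000 nM in this assay, at which 3 of the 3 values shown sit), no readable step exists to carry across. The step from compound 3 to compound 4 is expected to be a step that the limit leaves unreadable from compound 3 to compound 4, leaving compound 4 near the limit. Compound 4 is estimated at 150000 nM, with a range from 60000 nM to 400000 nM.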

Compound 4, half-maximal inhibitory concentration: > 100000 nM
Compound 4: only a limit was reported; the forecaster's own chance of this, stated with the estimate: 85%; the middle value is on the limit's open side.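

No size can be read for the change from benzyloxy to hydroxy between compound 3 and compound 4, as both give only a limit: the limit of > 100000 nM in this assay, at which 4 of the 4 values shown sit. The compounds shown leave open whether either core can give a readable value in this assay.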